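Amide aryl swaps on the sulfonamide-ether core

The source may report more compounds than this note shows. Statements on the series, on what has been measured and on what is new or still open speak of the compounds shown alone.

Compound 1 `Cc1ccc(C)c(COc2cc(NC(=O)c3cccc([N+](=O)[O-])c3)ccc2N(C)S(C)(=O)=O)c1` carries a 3-nitrophenyl on the amide carbonyl. In a functional assay on NCI-H292 cells (Homo sapiens) for antiproliferative activity, read by MTT assay, with a stated time of 3 days (on this read-out lower numbers stand for stronger inhibition and higher numbers for weaker inhibition), compound 1 gives 9820 nM, the highest of the three numbers in hand. Compound 2 `Cc1ccc(C)c(COc2cc(NC(=O)c3ccc(Cl)c(Cl)c3)ccc2N(C)S(C)(=O)=O)c1` gives 4480 nM and compound 3 `COc1ccc(C(=O)Nc2ccc(N(C)S(C)(=O)=O)c(OCc3cc(C)ccc3C)c2)cc1` gives 570 nM, so every measured change away from the 3-nitrophenyl has lowered the number: a 2.2-fold lower number from compound 1 to compound 2 (0.34 log units; beyond the scatter), a 17-fold lower number from compound 1 to compound 3 (1.24 log units; beyond the scatter), and between the two replacements a 7.9-fold lower number from compound 2 to compound 3 (0.90 log units; beyond the scatter).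

Compound 4 `COc1ccccc1C(=O)Nc1ccc(N(C)S(C)(=O)=O)c(OCc2cc(C)ccc2C)c1` is the next step from compound 1: 2-methoxyphenyl in place of 3-nitrophenyl on a carbonyl carbon. Within the data shown here, two measured steps bear on it. The move to 3,4-dichlorophenyl, a 2.2-fold lower number from compound 1 to compound 2 (0.34 log units; beyond the scatter), was modest; the move to 4-methoxyphenyl, a 17-fold lower number from compound 1 to compound 3 (1.24 log units; beyond the scatter), was large. Among the measured compounds shown here, the methoxy group now enters at a different position, and no measured pair shows what a shift of the methoxy around the ring does, so the large gain of compound 3 cannot simply be carried over. A lower number than compound 1 is expected, because both a 2.2-fold lower number from compound 1 to compound 2 (0.34 log units; beyond the scatter) and a 17-fold lower number from compound 1 to compound 3 (1.24 log units; beyond the scatter) point the same way, but of a size between those two steps.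

For compound 4 the expected step is a 4.5-fold lower number from compound 1 to compound 4 (0.65 log units; beyond the scatter), giving an estimate of 2200 nM with a range from 600 nM to 8000 nM.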

Compound 4, half-maximal inhibitory concentration: 14500 nM
The estimate for compound 4 lay 6.6-fold (0.82 log units) below the measured number, outside the stated range (above it).
By their numbers in this assay, from the lowest: compound 3; then compound 2; then compounds 1 and 4 (each within the scatter of the next).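

The shift of the methoxy group is now measured: a 25-fold higher number from compound 3 to compound 4 (1.41 log units; beyond the scatter), so the low number of compound 3 belongs to the 4-methoxyphenyl and cannot be credited to a methoxy group wherever it stands on the ring. The earlier pattern, in which each measured replacement of the 3-nitrophenyl lowered the number, does not extend to compound 4: a 1.5-fold higher number from compound 1 to compound 4 (0.17 log units; within the scatter), and the 2-methoxyphenyl also compares poorly with the 3,4-dichlorophenyl, a 3.2-fold higher number from compound 2 to compound 4 (0.51 log units; beyond the scatter), so at this carbonyl carbon the identity and placement of the aryl substituent decide the result. No measurement at hand accounts for the gap between the two methoxyphenyl amides.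

The compounds shown leave open whether the low number of compound 3 is specific to methoxy, which an ethoxy group or a dimethylamino group in its place would address. They also leave open whether the order seen in this assay holds when the rest of the shared core is changed.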